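Replacing the Chlorobenzyl Amide with a Carboxylic Acid

The source may hold more compounds than are shown below. What is called first, only, known or untested is meant among the compounds shown, and "the series" means these compounds.

Compound 1 `C=CC1=C(C(=O)NCc2ccc(Cl)cc2)C(c2ccc(OC)c(OC)c2)OC1`: > 100000 nM
Compound 2 `C=CC1=C(C(=O)NCc2ccc(Cl)cc2)C(c2ccc(OC)cc2)OC1`: > 100000 nM
Compound 3 `C=CC1=C(C(=O)NCCC)C(c2ccc(F)cc2)OC1`: > 100000 nM

Of the compounds shown here, three have been measured in a functional assay on HeLa cells (Homo sapiens) for cytotoxicity, read by MTT assay, with a stated time of 24 h; on this read-out lower numbers stand for stronger inhibition and higher numbers for weaker inhibition. Compound 1 gives only the limit of the assay, > 100000 nM. Compound 2 likewise gives only a limit, > 100000 nM. Compound 3 also gives only a limit, > 100000 nM. Among the measured compounds shown here, the single step between compounds differing in one place, a step that the two limits leave unreadable from compound 1 to compound 2, cannot be read in size, as both of its values are limits. the limit of > 100000 nM in this assay, at which 3 of the 3 values shown sit, is all the measured data show, and compound 1 stands at that limit rather than at a number.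

The unmeasured compound 4 `C=CC1=C(C(=O)O)C(c2ccc(OC)c(OC)c2)OC1` differs from compound 1 by hydroxy in place of (4-chlorobenzyl)amino on a carbonyl carbon. For the measured compounds named here, no measured step touches this change, and the only recorded step concerns another position and is unreadable. On this basis no step beyond the scatter in this assay can be expected, and compound 4 is most likely to sit at the limit again. Compound 4 is estimated at 150000 nM, with a range from 50000 nM to 500000 nM. This estimate implies a step that the limit leaves unreadable from compound 1 to compound 4 that is expected to stay within the scatter.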

Compound 4, half-maximal inhibitory concentration: 18000 nM
Compound 4: the middle estimate sits 8.3-fold (0.92 log units) above what was measured; measured number below the stated range.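

In this assay, the carbonyl carbon proves to be a place where a change can be read: hydroxy in place of (4-chlorobenzyl)amino brings an at least 5.5-fold lower number from compound 1 to compound 4 (0.74 log units; beyond the scatter). Among the compounds shown here, the earlier compounds showed nothing of this kind, as all of them stayed at a limit and the one step among them cannot be read. Compound 4 is the only compound shown that gives a number rather than a limit: the limit of > 100000 nM in this assay, at which 3 of the 4 values shown sit.

The compounds shown leave open whether the gain depends on the carboxylic acid itself or appears whenever (4-chlorobenzyl)amino leaves, which a methyl ester or a simple primary amide on the same carbonyl carbon would help to separate. Going by these compounds, it also remains open whether hydroxy at this place would give a number on the rest of compound 2 or compound 3.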